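The source may report more compounds than this note shows. Statements on the series, on what has been measured and on what is new or still open speak of the compounds shown alone.

Working notes on the series. For the measured compounds named here, compound 1 `COc1ccc(C(=O)Nc2ccncc2)cc1Nc1nccc(-c2cccnc2)n1` carries a pyridin-4-yl on the amide-type nitrogen; in a functional assay on K562 cells (Homo sapiens) for antiproliferative activity, read by MTT assay, with a stated time of 48 h (a higher number here means a weaker inhibitor, a lower number a stronger inhibitor), compound 1 gives 94500 nM, the highest of the two numbers measured so far. Compound 2 `COc1ccc(C(=O)Nc2cc(C(F)(F)F)cc(C(F)(F)F)c2)cc1Nc1nccc(-c2cccnc2)n1`, built on the same core, gives in this assay 4840 nM, a lower number, and the gap lies beyond the scatter. Going by the values given here, no pair of measured compounds differs in only one place, so the two values are simply set side by side. Compound 3 `COc1ccc(C(=O)Nc2cccc(C(C)=O)c2)cc1Nc1nccc(-c2cccnc2)n1` is still to be measured in this assay. It differs from compound 1 by 3-acetylphenyl in place of pyridin-4-yl on an amide-type nitrogen. Compound 2, which also bears a six-membered aromatic ring of carbon only on the amide-type nitrogen, gives 4840 nM, so a move from compound 1 toward such a ring is expected to lower the number. The step from compound 1 to compound 3 is expected as a 4.7-fold lower number from compound 1 to compound 3 (0.67 log units; beyond the scatter), beyond the scatter. Compound 3 is accordingly estimated at 20000 nM, with a range of 6000 nM to 60000 nM.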

Compound 3, half-maximal inhibitory concentration: 237000 nM
Estimate against measurement, compound 3: 12-fold (1.07 log units) below, outside the stated range (above it).
By their numbers in this assay, from the lowest: compound 2; then compound 1; then compound 3.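

In this assay, 3-acetylphenyl in place of pyridin-4-yl on the amide-type nitrogen gives a 2.5-fold higher number from compound 1 to compound 3 (0.40 log units; beyond the scatter) and so moves the number upward, a modest step. A six-membered aromatic ring of carbon only at this position therefore does not by itself bring a lower number: compound 2, with such a ring, gives 4840 nM, while compound 3, with such a ring, goes against that direction and gives 237000 nM in this assay. No measurement at hand accounts for this step.

The compounds shown do not separate the contribution of the ring from that of the acetyl group on it. A plain phenyl on the same nitrogen, or an amine or a carboxylic acid in place of the acetyl group, would bear on that question.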